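The compounds below may be only part of what the source reports. "The series", "measured", "known", "first", "only" and "open" are said of these compounds alone.

The compounds measured so far:

Compound 1, `O=C1c2cc(F)c(Cl)cc2CCN1c1cccnc1`, gives 3540 nM in an ADME assay on cells for inhibition of cytochrome P450 11B1, mitochondrial (Homo sapiens), read by HTRF; a higher number here means a weaker inhibitor, a lower number a stronger inhibitor.
Compound 2, `CC(=O)N[C@@H]1CCCc2c1cncc2N1C(=O)c2ccc(Cl)cc2[C@@H]1C1CC1`, gives > 30000 nM in this assay; this is a limit of the assay, not a number.
Compound 3, `CN(C(=O)c1ccc(C#N)cc1)c1cccnc1`, gives > 3000 nM in this assay; this too is a limit, not a number.

Compound 2 therefore stands at the limit of > 30000 nM in this assay, at which 1 of the 3 values shown sits. Among the compounds with values here, one further value among the three sits at the limit of > 3000 nM in this assay, at which 1 of the 3 values shown sits, so only compound 1 carries a real number in this assay, and the three measured compounds differ from one another in more than one place, so no single step between measured compounds can be read off.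

The piece turns from compound 2 to compound 4, `CC(=O)N[C@@H]1CCCc2c1cncc2N1C(=O)c2ccc(Cl)cc2[C@H]1C1CC1`. The change is this: the two compounds have the same atoms and bonds and differ only in configuration as drawn: 1 of 2 stereo elements differ; a stereocentre at a saturated ring carbon is drawn S in compound 2 and R in compound 4. Nothing enters and nothing leaves; the two compounds share every atom and bond.

With compound 2 only at a limit, the direction of such a step cannot be taken from the data. A change in configuration alone may leave a weak inhibitor weak, or it may uncover activity in the other epimer. The step from compound 2 to compound 4 is therefore expected to be an at least 2.5-fold lower number from compound 2 to compound 4 (0.39 log units; beyond the scatter), read with wide uncertainty. For compound 4 the estimate in this assay is 12000 nM, in the range 2000 nM to 30000 nM.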

Compound 4, half-maximal inhibitory concentration: 22800 nM
Compound 4: middle estimate off by 1.9-fold (0.28 log units), on the low side, and the stated range covers the measured number.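

Compound 4 gives this pair its first real number in this assay, so the change in configuration at the stereocentre at a saturated ring carbon, from S to R, can be read as a floor only: an at least 1.3-fold lower number from compound 2 to compound 4 (0.11 log units; that floor lies within the scatter). Compound 2 remains at a limit of the assay and not at a number: the limit of > 30000 nM in this assay, at which 1 of the 4 values shown sits. The earlier compounds shown here differed from one another in more than one place, whereas any gap in this pair can be placed at that single stereocentre alone: the fact that compounds 2 and 4 differ only in the configuration as drawn.

The compounds shown leave open how large the step truly is, whether it reaches beyond the scatter, and what the other stereo element, drawn alike in both compounds, contributes. They also leave open whether a primary amine in place of the acetamide, or a longer chain in place of the cyclopropyl group, would move the number in this assay on either epimer.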